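A few compounds are considered here, and "the series" means these few. Any claim that something is new, unique, unknown or untested is made for them only; others in the source may bear on it.

Measured compounds in this series:

Compound 1 `N=C(N)NCCC[C@H](NC(=O)CN(c1ncnc2c1ncn2C1CCCCO1)C1CC1)C(=O)OCc1ccccc1` – 52.4%
Compound 2 `O=C(O)C[C@H](NC(=O)CN(c1nc(Cl)nc2[nH]cnc12)C1CC1)C(=O)O` – 38.9%
Compound 3 `NC(=O)CC[C@H](NC(=O)CN(c1nc(Cl)nc2[nH]cnc12)C1CC1)C(=O)OCc1ccccc1` – 33.1%

All three numbers come from a functional assay on the whole organism (Tail, strain ICR) with Mus musculus as the target, in the tail flick test, with a stated time of 60 min, at a dose of 25 umol/kg by the oral route; a lower number here means a weaker effect, a higher number a stronger effect of the compound at the dose given. Compound 2 stands second highest of the three. Its nearest neighbour is compound 3, whose number lies a little lower but within the usual scatter, so no order between compound 2 and compound 3 can be read from these two values. Compound 1 gives the number furthest from compound 2, and that gap lies beyond the scatter, so compound 1 shows the stronger effect of the pair.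

Within the data shown here, no two measured compounds differ in only one place, so the series gives no direct guide to the size of a single structural step. Compound 4 `CC(C)[C@H](NC(=O)CN(c1nc(Cl)nc2[nH]cnc12)C1CC1)C(=O)O` is not yet measured. It differs from compound 2 in one place: isopropyl in place of carboxymethyl on a saturated chain carbon bound to an amide-type nitrogen and a carbonyl carbon.

Among the measured compounds shown here, with no comparable single step among the measured compounds, the expectation in this assay for the step from compound 2 to compound 4 is a change that stays within the scatter, in either direction, with the estimated step being a number 2.1 percentage points higher from compound 2 to compound 4 (within the scatter). The estimate for compound 4 is therefore 41%, expected to fall between 24% and 58%.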

Compound 4, a percentage reported as activity, at one dose (the size of the read-out at that dose, not a potency): 38.8%
Estimate against measurement, compound 4: 2.2 percentage points above, and the stated range covers the measured number.
By their numbers in this assay, from the lowest: compounds 3, 4 and 2 (each within the scatter of the next); then compound 1.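

In this assay, the series now has its first single-place step, on a saturated chain carbon bound to an amide-type nitrogen and a carbonyl carbon: a number 0.1 percentage points lower from compound 2 to compound 4 (within the scatter). Carboxymethyl, with 4 heavy atoms, 1 hydrogen-bond donor and 1 hydrogen-bond acceptor, gives way to isopropyl, with 3 heavy atoms and 0 hydrogen-bond donors or acceptors, and the read-out at this dose shows no change beyond the scatter, so in this pair the effect at this dose does not depend on the carboxymethyl group being present at this position. The compounds shown offer no measurement that could explain this outcome.

A single pair leaves open whether other groups at this position, such as an aminobutyl chain, a hydroxymethyl group or a longer carboxylic acid chain, would also leave the read-out within the scatter. It also leaves open whether the same swap would give a comparable step on a different core or with a benzyl ester in place of the remaining carboxylic acid.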